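Triazole nitrogen substituent series: from chains to a ring

The compounds below may be only part of what the source reports. "The series", "measured", "known", "first", "only" and "open" are said of these compounds alone.

compound 1 `CCCCCn1nc(C(=O)N[C@H]2COc3ccccc3N(C)C2=S)nc1Cc1ccccc1` — 805 nM
compound 2 `CC(C)CCn1nc(C(=O)N[C@H]2COc3ccccc3N(C)C2=S)nc1Cc1ccccc1` — 3640 nM
compound 3 `CN1C(=S)[C@@H](NC(=O)c2nc(Cc3ccccc3)n(CCCCC#N)n2)COc2ccccc21` — 2680 nM

In a functional assay on HT-29 cells (Homo sapiens) for inhibition, read by luminescence and CellTiter-Glo, with a stated time of 24 h (on this read-out higher numbers stand for an effect only at larger amounts of compound and lower numbers for an effect already at smaller amounts), compound 3 sits second highest of the three numbers; against compound 2 the two values lie within the scatter, while a 3.3-fold higher number from compound 1 to compound 3 (0.52 log units; beyond the scatter). Compound 4 `CN1C(=S)[C@@H](NC(=O)c2nc(Cc3ccccc3)n(C3CCN(C(=O)OC(C)(C)C)C3)n2)COc2ccccc21` carries a group of 12 heavy atoms (9 carbon, 1 nitrogen, 2 oxygen; one five-membered non-aromatic ring with 1 hetero atom) in place of a group of 6 heavy atoms (5 carbon, 1 nitrogen; no ring), on an aromatic nitrogen. The measured steps all vary the saturated chain on this aromatic nitrogen: a 4.5-fold higher number from compound 1 to compound 2 (0.66 log units; beyond the scatter) and a 3.3-fold higher number from compound 1 to compound 3 (0.52 log units; beyond the scatter), whereas a 1.4-fold lower number from compound 2 to compound 3 (0.13 log units; within the scatter). None of them introduces a ring, so they bear on the change only by showing that groups on this aromatic nitrogen move the number modestly. The expected step is a 1.1-fold higher number from compound 3 to compound 4 (0.05 log units; within the scatter), small and of uncertain direction, with a wide range. For compound 4 the estimate in this assay is 3000 nM, within 800 nM to 12000 nM.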

Compound 4, half-maximal effective concentration: > 10000 nM
Compound 4 ended at the assay's limit (the forecaster's own chance of this, stated with the estimate: 10%); middle value at least 3.3-fold (0.52 log units) from the limit.
By their numbers in this assay, from the lowest: compound 1; then compounds 3 and 2 (each within the scatter of the next). At a limit, above all of these: compound 4.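

In this assay compound 4 gives > 10000 nM as a limit of the assay and not a number: the limit of > 10000 nM in this assay, at which 1 of the 4 values shown sits.

Going by these compounds alone, at this aromatic nitrogen, the ring-bearing group shows an at least 3.7-fold higher number from compound 3 to compound 4 (0.57 log units; beyond the scatter) and an at least 2.7-fold higher number from compound 2 to compound 4 (0.43 log units; beyond the scatter) and, as the only large step, an at least 12-fold higher number from compound 1 to compound 4 (1.09 log units; beyond the scatter) in these comparisons. The position is therefore less forgiving of this group than the chain changes alone suggested.

As far as these compounds go, whether the ring itself or the rest of the group drives this stays open. A free amine on the same ring, or a longer chain, would help separate the two.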